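A few compounds are considered here, and "the series" means these few. Any claim that something is new, unique, unknown or untested is made for them only; others in the source may bear on it.

Measured compounds and their values:

compound 1, `COc1cc(Oc2cccc(Nc3ccccc3)c2)cc(OC)c1CNCc1ccccc1`: 5020 nM
compound 2, `COc1cc(Oc2cccc(Nc3ccccc3)c2)cc(OC)c1CNCc1ccc(Cl)cc1`: 4850 nM

In a functional assay on HCT-15 cells (Homo sapiens) for inhibition, read by MTT assay, with a stated time of 72 h (a lower number here means a stronger inhibitor, a higher number a weaker inhibitor), compound 1 gives 5020 nM. Within the data shown here, of the two numbers measured so far this is the higher one, but the nearest value, that of compound 2 at 4850 nM, stands so close that the two cannot be told apart: the step of a 1.0-fold lower number from compound 1 to compound 2 (0.01 log units; within the scatter), a chloro in place of hydrogen on an aromatic carbon, lies within the scatter.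

Compound 3, `COc1cc(Oc2cccc(Nc3ccccc3)c2)cc(OC)c1CNC(C)C`, has not yet been measured in this assay. It differs from compound 1 in one place: isopropyl in place of benzyl on an amine nitrogen. Among the measured compounds shown here, the only measured step, from compound 1 to compound 2, changes a substituent on the benzyl group that here leaves altogether, and it produced no change beyond the scatter. For the measured compounds named here, no measured pair tests the benzyl-to-isopropyl exchange itself, so there is no direct guide to its size or direction.

With that thin evidence, compound 3 is expected to stay near the neighbours, at an estimated 5500 nM, within 2000 nM to 15000 nM. This amounts to an expected step of a 1.1-fold higher number from compound 1 to compound 3 (0.04 log units; within the scatter).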

Compound 3, half-maximal inhibitory concentration: > 20000 nM
Compound 3: only a limit was reported; the forecaster's own chance of this, stated with the estimate: 10%; middle value at least 3.6-fold (0.56 log units) from the limit.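

Until now, this amine nitrogen had carried only benzyl groups, and adding chloro to the ring made no difference beyond the scatter, so the position seemed to tolerate change. Replacing the whole group with isopropyl, which removes the aromatic ring, shows that the position is far less forgiving: in this assay there is an at least 3.9-fold higher number from compound 1 to compound 3 (0.60 log units; beyond the scatter), and the chlorinated partner gives an at least 4.1-fold higher number from compound 2 to compound 3 (0.61 log units; beyond the scatter). Both steps are minimum sizes and the real loss of strength could be larger, because compound 3 was read only as a limit of the assay: the limit of > 20000 nM in this assay, at which 1 of the 3 values shown sits.

Isopropyl differs from benzyl both in lacking the ring and in having fewer heavy atoms, so the compounds shown cannot say which of these differences matters. A cyclohexylmethyl group would keep a ring but not an aromatic one, and a phenethyl group would set the aromatic ring on a longer chain, so how either would read in this assay remains an open question.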